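Benzyl exchange on the amide series: compound 3 to compound 4

The source may report more compounds than this note shows. Statements on the series, on what has been measured and on what is new or still open speak of the compounds shown alone.

In a functional assay on A-375 cells (Homo sapiens) for antiproliferative activity (a higher number here means a weaker inhibitor, a lower number a stronger inhibitor), compound 3 `O=C(Nc1ccc(-c2cscn2)cc1)C1CCCN(Cc2ccccc2F)C1` gives 4000 nM. Compound 2 `O=C(Nc1ccc(-c2cscn2)cc1)[C@@H]1CCCN(Cc2ccc(F)c(F)c2)C1` gives 6000 nM, within the scatter of the value for compound 3. Compound 1 `O=C(Nc1ccc(-c2cscn2)cc1)C1CN(Cc2ccc(F)c(F)c2)C1` reports only a limit, > 20000 nM. Within the data shown here, compound 3 therefore stands level with compound 2, and these two are the only numerical values in the set.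

Compound 4 `O=C(Nc1ccc(-c2cscn2)cc1)C1CCCN(Cc2ccc(Cl)c(Cl)c2)C1` carries 3,4-dichlorophenyl in place of 2-fluorophenyl on a saturated chain carbon bound to an amine nitrogen in a ring. The same difference reads 2-fluorobenzyl to 3,4-dichlorobenzyl. Among the measured compounds shown here, no measured pair isolates this change in this assay. With differently substituted benzyl groups, compound 3 and compound 2 at 6000 nM stay within the scatter, so no step beyond the scatter is expected in this assay. The expected change is small, and the estimated step is a 1.1-fold lower number from compound 3 to compound 4 (0.06 log units; within the scatter). The estimate for compound 4 is 3500 nM, with an expected range of 1200 nM to 10000 nM.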

Compound 4, half-maximal inhibitory concentration: 1730 nM
The estimate for compound 4 lay 2.0-fold (0.31 log units) above the measured number; measured number inside the range.
By their numbers in this assay, from the lowest: compound 4; then compounds 3 and 2 (each within the scatter of the next). At a limit, above all of these: compound 1.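

Among these compounds, exchanging 2-fluorobenzyl for 3,4-dichlorobenzyl gives a 2.3-fold lower number from compound 3 to compound 4 (0.36 log units; beyond the scatter) in this assay, the first single-place change that can be read. This shows that the group on the ring amine nitrogen can shift the antiproliferative read-out, though only modestly here. Nothing measured in the set accounts for the step.

The exchange alters the halogen and the number of halogens on the phenyl ring together, so this one pair cannot separate those two changes, and a 4-chlorobenzyl or 2-chlorobenzyl group would be needed to pull them apart. It also leaves open how this position responds to non-halogen groups on that phenyl ring, such as a methoxy group, an amine or a carboxylic acid.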